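The source may report more compounds than this note shows. Statements on the series, on what has been measured and on what is new or still open speak of the compounds shown alone.

The study compares a small set of compounds that share one core, read in a functional assay on NCI-H226 cells (Homo sapiens) for inhibition, read by MTT assay, with a stated time of 48 h, tested at 10 uM; a lower number here means less inhibition, a higher number more inhibition at the concentration tested (going by the name of the read-out). Compound 1, `Cc1ccc(Nc2cc(NC(=O)Nc3c(Cl)cccc3Cl)ncn2)cc1F`, gives 40.7% in this assay. Compound 2, `CCc1ccc(Nc2cc(NC(=O)Nc3cc(OC)cc(OC)c3)ncn2)cc1`, gives 50.1%. The two numbers lie within the usual scatter of each other, so on the numbers shown compound 1 cannot be separated from compound 2, and it has no measured neighbour that differs from it in a single place.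

Compound 3, `Cc1ccc(Nc2cc(NC(=O)Nc3c(Cl)cccc3Cl)ncn2)cc1C`, has not yet been measured. It differs from compound 1 in one place: methyl in place of fluoro on an aromatic carbon. Put more broadly, the (3-fluoro-4-methylphenyl)amino part of compound 1 becomes the (3,4-dimethylphenyl)amino part of compound 3.

Among the measured compounds shown here, no measured pair in this set shows what such an exchange does here, so the expectation rests only on the value of compound 1 and on the single-atom size of the change. Compound 3 is expected to give about 42% in this assay, within a range from 25% to 60%. The expected step, a number 1.3 percentage points higher from compound 1 to compound 3 (within the scatter), is not expected to go beyond the usual scatter in either direction.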

Compound 3, a percentage reported as inhibition, at one concentration (the size of the read-out at that concentration, not a potency): 41.3%
For compound 3 the middle estimate is 0.7 percentage points above the measured one; measured number inside the range.
By their numbers in this assay, from the lowest: compounds 1, 3 and 2 (each within the scatter of the next).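

In this assay, among the compounds shown here, the exchange of fluoro for methyl on this aromatic carbon gives the only single-place step in the set, a number 0.6 percentage points higher from compound 1 to compound 3 (within the scatter), which the earlier compounds could not provide. At this place, ortho to a methyl group and meta to a large group, the two groups therefore cannot be told apart by this read-out, and the 3-fluoro-4-methylphenyl and 3,4-dimethylphenyl parts fit the same level of inhibition at the concentration tested. Nothing on hand accounts for this result, and no property of either group has been measured here.

For the compounds shown here, the step covers only two groups of one heavy atom each, so it remains open whether a methoxy group, an ethyl or longer chain, or a dimethylamino group at this place would move the number beyond the scatter. Also open, as far as these compounds go, is what the other end of the molecule contributes, as compound 2 differs from compound 1 and compound 3 in more than one place and no single change connects it to them.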